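Sulfur-bearing side chains on the core of compound 1

The source may report more compounds than this note shows. Statements on the series, on what has been measured and on what is new or still open speak of the compounds shown alone.

Compound 1 `Cc1cn2cccc(OCc3ccccc3)c2n1` is the reference point of the series. For the measured compounds named here, in a functional assay on the whole organism (stomach) for inhibition, with Canis familiaris (Canis lupus familiaris) as the target, at a dose of 5 mg/kg by the intravenous route (on this read-out higher numbers stand for a stronger effect at the one dose given and lower numbers for a weaker effect), compound 1 gives 70%, the highest of the three numbers measured so far, and the steps to both other compounds lie beyond the scatter. Compound 2 `CSCc1c(C)nc2c(OCc3ccccc3)cccn12`, which carries a (methylsulfanyl)methyl group on an aromatic carbon of the shared core, gives 8% in this assay. Compound 3 `Cc1nc2c(OCc3ccccc3)cccn2c1C[S+](C)[O-]`, with a group of 4 heavy atoms (2 carbon, 1 oxygen, 1 sulfur; no ring) in place of a hydrogen on that aromatic carbon, gives 18%.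

The step to compound 4 `Cc1nc2c(OCc3ccccc3)cccn2c1CS(C)(=O)=O` is (methylsulfonyl)methyl in place of hydrogen on an aromatic carbon. The measured steps that bear on it are a number 62 percentage points lower from compound 1 to compound 2 (beyond the scatter) and a number 52 percentage points lower from compound 1 to compound 3 (beyond the scatter); in both cases the replacement of the same hydrogen by a sulfur-containing chain is followed by a large loss. Compound 2 and compound 3 lie within the scatter of each other, as a number 10 percentage points higher from compound 2 to compound 3 (within the scatter) shows. Since compound 4 carries the (methylsulfonyl)methyl group at the same place, a large drop in this assay from compound 1 is expected, of about the size of the two measured ones. Compound 4 is therefore estimated at 15% in this assay, with a range from 0% to 40%. The step this estimate implies is expected to be a number 55 percentage points lower from compound 1 to compound 4 (beyond the scatter).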

Compound 4, a percentage reported as inhibition, in the whole organism at one dose (the size of the read-out at that dose, not a potency): 0%
Beside the measured number, compound 4's estimate is 15 percentage points above it, within the range that was stated.
By their numbers in this assay, from the lowest: compounds 4, 2 and 3 (each within the scatter of the next, the first and the last beyond it); then compound 1.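

In this assay, the loss on this aromatic carbon holds for a third sulfur-bearing chain, with (methylsulfonyl)methyl in place of hydrogen giving a number 70 percentage points lower from compound 1 to compound 4 (beyond the scatter). Changes at the sulfur end of the chain do not all register alike: a number 18 percentage points lower from compound 3 to compound 4 (beyond the scatter), so the sulfonyl chain is separated from the chain of compound 3, whereas methylsulfonyl in place of methylsulfanyl gives a number 8 percentage points lower from compound 2 to compound 4 (within the scatter), which does not separate those two. No supporting measurement bears on why these chains behave this way, so the result stands as an observation only.

The compounds shown leave open whether the loss goes with sulfur in the chain or with any substitution at this carbon, and what a plain ethyl group, a hydroxymethyl group or an aminomethyl group would give there remains an open question. Also open, from the compounds shown here alone, is whether the order among the three sulfur-bearing chains would hold at other doses, given that the read-out reports the size of the effect at a single dose and is not a potency.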